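Aryl urea series: fluoro added to the trifluoromethyl-bearing ring

A few compounds are considered here, and "the series" means these few. Any claim that something is new, unique, unknown or untested is made for them only; others in the source may bear on it.

Measured so far in an ADME assay on the whole organism with Oryza sativa as the target, tested at 10 uM; on this read-out lower numbers stand for a stronger effect and higher numbers for a weaker effect at the one concentration tested:
- compound 1, `C[C@H](NC(=O)Nc1cccc(C(F)(F)F)c1)c1ccccc1`: 92%
- compound 2, `C[C@H](NC(=O)Nc1cc(C(F)(F)F)cc(C(F)(F)F)c1)c1ccccc1`: 86%

Compound 1 stands alongside compound 2 on the two numbers shown; the only measured step, a number 6 percentage points lower from compound 1 to compound 2 (within the scatter), does not separate them, so both sit at the weak end of this assay with no order between them.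

Compound 3, `C[C@H](NC(=O)Nc1cc(C(F)(F)F)ccc1F)c1ccccc1`, is not yet measured. It differs from compound 1 in one place: fluoro in place of hydrogen on an aromatic carbon.

Among the compounds with values here, the one measured step bears on it only loosely: it concerns a trifluoromethyl in place of hydrogen on the same ring, and it stayed within the scatter. Nothing measured suggests that a single fluorine on that ring moves this assay. The expected step from compound 1 to compound 3 is therefore small, a number 4 percentage points lower from compound 1 to compound 3 (within the scatter), with no direction beyond the scatter claimed.

Compound 3 is estimated at 88%, with a range of 76% to 98%.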

Compound 3, a percentage reported as activity, at one concentration (the size of the read-out at that concentration, not a potency): 87%
The estimate for compound 3 lay 1 percentage points above the measured number; low and high end bracket the measured number.
By their numbers in this assay, from the lowest: compounds 2, 3 and 1 (each within the scatter of the next).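

In this assay, fluoro in place of hydrogen on an aromatic carbon, ortho to a large group and para to a trifluoromethyl group, gives a number 5 percentage points lower from compound 1 to compound 3 (within the scatter) and does not separate the two compounds. Within the data shown here, this is the only reading at this position of the ring, and with a single fluorine there compound 3 remains at the weak end of the read-out alongside compound 1. No supporting data bear on the reason for this result.

Going by these compounds, whether an amine or a carboxylic acid at this same position would give a step beyond the scatter in this assay remains open. On these data alone, it is also open whether a methoxy group or a longer alkyl chain there would separate from compound 1 on this read-out.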